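The compounds below may be only part of what the source reports. "The series", "measured", "known", "first", "only" and "open" are said of these compounds alone.

Series notes, H3 lysine-79 methyltransferase binding.

Compound 1 `C(=C/c1nn2c(-c3ccncc3)nnc2s1)\c1ccco1` gives 82% in an assay for inhibition of histone-lysine N-methyltransferase, H3 lysine-79 specific (Homo sapiens), read by scintillation counting, with stated times of 15 min and 60 min, tested at 100 uM, in the presence of a further agent that is not named here; a higher number here means a stronger effect of the compound at the concentration tested, a lower number a weaker effect. Among the compounds with values here, compound 2 `Fc1ccc(-c2nnc3sc(/C=C/c4ccco4)nn23)cc1` gives 40% in this assay, and compound 3 `Fc1cccc(-c2nnc3sc(/C=C/c4ccco4)nn23)c1` gives 29% in this assay, the lowest of the three numbers measured so far. The steps are a number 42 percentage points lower from compound 1 to compound 2 (beyond the scatter) and a number 53 percentage points lower from compound 1 to compound 3 (beyond the scatter), both large, while the step of a number 11 percentage points lower from compound 2 to compound 3 (beyond the scatter) is modest.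

Compound 4 `Cc1cccc(-c2nnc3sc(/C=C/c4ccco4)nn23)c1` is the next one to be measured. It differs from compound 3 by methyl in place of fluoro on an aromatic carbon. Within the data shown here, no measured step exchanges fluoro for methyl, so the change itself has no direct precedent here. Among the measured compounds shown here, the only step touching a group on an aromatic carbon of this ring is a number 11 percentage points lower from compound 2 to compound 3 (beyond the scatter), which was modest; the large steps concern the exchange of pyridin-4-yl for a fluorophenyl and do not bear on compound 4. A step within the scatter, or at most a modest one in either direction, is therefore expected in this assay. Compound 4 is expected to give about 30% in this assay, within 12% to 50%. The expected step is a number 1 percentage points higher from compound 3 to compound 4 (within the scatter).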

Compound 4, a percentage reported as inhibition, at one concentration (the size of the read-out at that concentration, not a potency): 74%
Compound 4: middle estimate off by 44 percentage points, on the low side, outside the stated range (above it).
By their numbers in this assay, from the lowest: compound 3; then compound 2; then compounds 4 and 1 (each within the scatter of the next).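

The exchange of fluoro for methyl on this aromatic carbon, meta to a large group, is a large change in this assay: a number 45 percentage points higher from compound 3 to compound 4 (beyond the scatter), well beyond the earlier a number 11 percentage points lower from compound 2 to compound 3 (beyond the scatter) between the two fluorophenyl compounds. The 3-methylphenyl group also gives a number 34 percentage points higher from compound 2 to compound 4 (beyond the scatter), and with a number 8 percentage points lower from compound 1 to compound 4 (within the scatter), pyridin-4-yl is shown not to be required for a high number in this small set. Nothing available here accounts for the gap between methyl and fluoro at this place.

Going by these compounds, whether an ethyl, a methoxy or an amine at the same place would behave like methyl or like fluoro remains open. On these data alone, these read-outs come from a single concentration and give the size of the effect at that concentration only, so how compound 4 and compound 1 compare at other concentrations also remains open.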